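The source may report more compounds than this note shows. Statements on the series, on what has been measured and on what is new or still open speak of the compounds shown alone.

Working notes on the series. Compound 1 `CC(C)n1nc(-c2cc(C3CCCCC3)on2)c2c(N)ncnc21` is the cyclohexyl member of the shared core. In an assay on TT cells for inhibition of proto-oncogene tyrosine-protein kinase receptor Ret variant C634W (Homo sapiens), read by MTT assay, with a stated time of 10 days (a higher number here means a weaker inhibitor of growth, a lower number a stronger inhibitor of growth), compound 1 gives > 10000 nM, which is a limit of this assay rather than a number, so compound 1 stands at the edge of what is measured here. The record for this point is the limit of > 10000 nM in this assay, at which 1 of the 2 values shown sits. Compound 2 `CC(C)(O)Cn1nc(-c2cc(C3CC3)on2)c2c(N)ncnc21` differs from compound 1 in several places. In this assay compound 2 gives 4250 nM. Going by the values given here, with no single step joining the two, their values show only that compound 2 falls inside the measured range and compound 1 does not.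

Compound 3 `CCc1cc(-c2nn(C(C)C)c3ncnc(N)c23)no1` is derived from compound 1 by ethyl in place of cyclohexyl on an aromatic carbon. Among the compounds with values here, no measured step shows what such a change does, so the direction is open. The expected step is an at least 1.2-fold lower number from compound 1 to compound 3 (0.09 log units; that floor lies within the scatter), a shift not clearly beyond the scatter, with compound 1 sitting at a limit in this assay. Compound 3 is expected at 8000 nM, within 2000 nM to 30000 nM, with a sizeable chance that this assay again reports only a limit.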

Compound 3, concentration for 50% growth inhibition: 2610 nM
Beside the measured number, compound 3's estimate is 3.1-fold (0.49 log units) above it, and the stated range covers the measured number.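

Going by these compounds alone, at this position, on an aromatic carbon next to the ring oxygen, ethyl in place of cyclohexyl gives an at least 3.8-fold lower number from compound 1 to compound 3 (0.58 log units; beyond the scatter) in this assay, and this is the only change in one place that the series can yet be read on. It shows that this position is not indifferent to its group, and that for this pair the change from a six-membered carbon ring to ethyl brings the value into the measured range. The value of compound 1 is a limit of the assay, so the step gives a floor and not a size: the limit of > 10000 nM in this assay, at which 1 of the 3 values shown sits.

As far as these compounds go, whether the gain comes from losing the ring or from having fewer carbons stays open, and compound 2, which carries cyclopropyl here, differs in several places and cannot settle it. From the compounds shown here alone, it is also open how a methyl, a longer chain such as butyl, or an amine would behave on this same carbon, and so whether the values follow any trend with the group at this position.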